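The compounds below may be only part of what the source reports. "The series", "measured", "known", "first", "only" and "open" are said of these compounds alone.

Measured so far in an ADME assay on Huh-7 cells (Homo sapiens) for cytotoxicity, read by MTT assay, with a stated time of 72 h; on this read-out higher numbers stand for lower toxicity in this test and lower numbers for higher toxicity in this test:

Compound 1, `COc1cc(O)c(C(=O)/C=C/c2ccc(OC)c(OCc3cn(-c4ccccc4Cl)nn3)c2)c(OC)c1`: in this assay compound 1 gives a limit, > 100 ug/mL.
Compound 2, `COc1cc(O)c(C(=O)/C=C/c2ccc(OC)c(OCc3cn(-c4ccc(F)c(Cl)c4)nn3)c2)c(OC)c1`: in this assay compound 2 gives a limit, > 100 ug/mL.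
Compound 3, `COc1cc(OC)c2c(=O)cc(-c3ccc(OCc4cn(-c5ccc(F)c(Cl)c5)nn4)c(OC)c3)oc2c1`: in this assay compound 3 gives a limit, > 100 ug/mL.

Compounds 1 and 2 share one core and differ only in the change (2-chlorophenyl in place of 3-chloro-4-fluorophenyl on an aromatic nitrogen). Its size is not readable, a step that the two limits leave unreadable from compound 2 to compound 1, since both values are limits. All three sit at the same point, (the limit of > 100 ug/mL in this assay, at which 3 of the 3 values shown sit). Compound 3 carries a different core; how the two cores differ is not broken down here.

Compound 4, `COc1cc(OC)c2c(=O)cc(-c3ccc(OCc4cn(-c5ccccc5Cl)nn4)c(OC)c3)oc2c1`, has the core of compound 3 and carries the same change, (2-chlorophenyl in place of 3-chloro-4-fluorophenyl on an aromatic nitrogen). In this assay the step is expected to be small, a number no higher from compound 3 to compound 4 (the limit leaves the size open), since compound 3 sits at a limit, > 100 ug/mL. Compound 4 is therefore expected at about 100 ug/mL, between 50 ug/mL and 100 ug/mL.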

Compound 4, half-maximal cytotoxic concentration: > 100 ug/mL
Compound 4: a limit, no number (the forecaster's own chance of this, stated with the estimate: 85%); the middle value lies on the limit itself.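

Compound 3 and compound 4 each give only a limit, so the step between them cannot be read: the limit of > 100 ug/mL in this assay, at which 4 of the 4 values shown sit.

What stays open is the actual value of each of these compounds in this assay, and whether 2-chlorophenyl in place of 3-chloro-4-fluorophenyl changes it.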